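A Methoxy for Fluoro Swap at the Assay Ceiling

The source may report more compounds than this note shows. Statements on the series, on what has been measured and on what is new or still open speak of the compounds shown alone.

The series shares one core, seen in compound 1 `COc1cc(-c2nnc3n2NC(c2ccco2)C(C(=O)c2ccccc2F)S3)cc(OC)c1OC`, compound 2 `COc1cc(-c2nnc3n2NC(c2ccco2)C(C(=O)c2ccc(Cl)cc2)S3)cc(OC)c1OC` and compound 3 `COc1cc(-c2nnc3n2NC(c2ccco2)C(C(=O)c2ccc(F)cc2)S3)cc(OC)c1OC`, and differs only in the aryl group on the carbonyl carbon. In a functional assay on MCF7 cells (Homo sapiens) for cytotoxicity, read by MTT assay, with a stated time of 48 h (a lower number here means a stronger inhibitor, a higher number a weaker inhibitor), compound 1 gives 94800 nM. In this assay compound 2 gives > 100000 nM, which is a limit of the assay and not a number. In this assay compound 3 likewise gives > 100000 nM, again a limit. Compound 3 therefore stands at the ceiling of what was measured, as the limit of > 100000 nM in this assay, at which 2 of the 3 values shown sit, records. The step of an at least 1.0-fold higher number from compound 1 to compound 2 (0.02 log units; that floor lies within the scatter) and the step of an at least 1.0-fold higher number from compound 1 to compound 3 (0.02 log units; that floor lies within the scatter) both lie within the scatter, and the step that the two limits leave unreadable from compound 2 to compound 3 cannot be read at all.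

Compound 4 `COc1ccc(C(=O)C2Sc3nnc(-c4cc(OC)c(OC)c(OC)c4)n3NC2c2ccco2)cc1` arises from compound 3 by the change (methoxy in place of fluoro on an aromatic carbon). The measured steps show that changing the aryl substituent on the carbonyl carbon has not moved this assay beyond its ceiling, so no step beyond the scatter is expected for the change from compound 3 to compound 4, with a step that the limit leaves unreadable from compound 3 to compound 4 as the estimated step. Compound 4 is therefore expected to give about 110000 nM in this assay, within a range from 50000 nM to 300000 nM, most likely reported again only as a limit.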

Compound 4, half-maximal inhibitory concentration: > 100000 nM
Compound 4: no number, only a limit; the forecaster's own chance of this, stated with the estimate: 70%; the middle value lies beyond the limit too.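

Compound 3's fluoro and compound 2's chloro had left open whether any 4-substituent could register in this assay, and the 4-methoxyphenyl group of compound 4, with its added oxygen, does not change that picture. In this assay compound 4 gives > 100000 nM, which is a limit of the assay and not a number. Among these compounds, only compound 1, the 2-fluorophenyl member, carries a number, and the one readable step, an at least 1.0-fold higher number from compound 1 to compound 4 (0.02 log units; that floor lies within the scatter), does not separate it from the rest; the steps between the limits cannot be read. The position therefore now has three different groups at the same ceiling: the limit of > 100000 nM in this assay, at which 3 of the 4 values shown sit.

As far as these compounds go, whether an amine or a carboxylic acid on this phenyl ring would give a measurable number remains open. So does any ranking of compound 2, compound 3 and compound 4.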